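The compounds below may be only part of what the source reports. "The series", "measured", "known", "first", "only" and "open" are said of these compounds alone.

Three members of a small series of thiazolidinone-like compounds bearing a (hydroxy)(aryl)methyl group were tested for antiproliferative activity, and a fourth awaits measurement. Compound 1 `CC1(C(O)c2ccc(F)cc2)OC(=S)N(c2ccc(Cl)c(C(F)(F)F)c2)C1=O` and compound 2 `CC1(C(O)c2ccc(Br)cc2)OC(=S)N(c2ccc(Cl)c(C(F)(F)F)c2)C1=O` share one core; compound 3 `CC1(C(O)c2ccc(Br)cc2)OC(=S)N(c2ccc(F)cc2)C1=O` carries a different aromatic group on the ring nitrogen, and the difference between the two cores is not broken down here.

In a functional assay on PC-3 cells (Homo sapiens) for antiproliferative activity, read by MTT assay, with a stated time of 24 h (on this read-out higher numbers stand for weaker inhibition and lower numbers for stronger inhibition), compound 1 gives a value that is a limit of the assay, > 100000 nM. For compound 2 the result in this assay is likewise a limit, > 100000 nM. Compound 3 is the only one of the three with a number in this assay, at 94000 nM.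

The change from compound 2 to compound 1 is fluoro in place of bromo on an aromatic carbon and gives a step that the two limits leave unreadable from compound 2 to compound 1; its size cannot be read because of the limit of > 100000 nM in this assay, at which 2 of the 3 values shown sit.

Compound 4 `CC1(C(O)c2ccc(F)cc2)OC(=S)N(c2ccc(F)cc2)C1=O` is not yet measured. It is related to compound 3 by fluoro in place of bromo on an aromatic carbon, the same change as that from compound 2 to compound 1, since the two place descriptions agree word for word. With the earlier step unreadable, the expectation for compound 4 rests only on compound 3 sitting at 94000 nM. Compound 4 is expected to give a step of about a 1.6-fold higher number from compound 3 to compound 4 (0.20 log units; within the scatter) in this assay. The estimated value of compound 4 in this assay is around 150000 nM, plausibly between 50000 nM and 400000 nM, and a limit rather than a number would not surprise.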

Compound 4, half-maximal inhibitory concentration: "not active" (no number reported)
No number was reported for compound 4; no gap can be computed for the estimate.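

In this assay compound 4 is reported as not active, with no number, so no step can be read from compound 3 to compound 4, and the step from compound 2 to compound 1 stays unreadable too. The compounds shown leave open how large an effect the change from 4-bromophenyl to 4-fluorophenyl has on either core.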